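The source may hold more compounds than are shown below. What is called first, only, known or untested is meant among the compounds shown, and "the series" means these compounds.

Measured compounds:
Compound 1 `COc1ccc2nc(NC(=O)CNC(=O)c3nn(-c4ccccc4OC)c(=O)c4ccccc34)sc2c1` — 90 nM
Compound 2 `O=C(CSc1nc2c(c(=O)n1-c1ccccc1)SCC2)Nc1nc(-c2ccccc2)cs1` — 350 nM
Compound 3 `CN(C)c1ccc(NC(=O)CSc2nc3c(c(=O)n2-c2ccccc2)SCC3)cc1` — > 1000 nM

In an assay on L cells for inhibition of Protein-serine O-palmitoleoyltransferase porcupine (Mus musculus), read by reporter gene assay, with a stated time of 24 h (a higher number here means that more compound is needed for the effect, a lower number that less compound is needed), compound 1 gives 90 nM and compound 2 gives 350 nM. For compound 3 the result > 1000 nM is a limit of the assay, not a measured number. Compound 3 therefore sits at the edge of what the assay could resolve, where (the limit of > 1000 nM in this assay, at which 1 of the 3 values shown sits). Among the compounds with values here, of the three compounds it is the only one for which no number was obtained, so its standing is known only as a range.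

The next compound, compound 4 `O=C(CSc1nc2c(c(=O)n1-c1ccccc1)SCC2)Nc1ccc(N2CCCCC2)cc1`, shares the core of compound 3 and differs in one place: piperidin-1-yl in place of dimethylamino on an aromatic carbon. Within the data shown here, no measured pair differs in this way, so there is no measured step to lean on. With compound 3 already at a limit and both groups being uncharged amine substituents without hydrogen-bond donors, compound 4 is expected to stay near compound 3, a step that the limit leaves unreadable from compound 3 to compound 4 that is not expected to go beyond the scatter. Compound 4 is thus estimated at 2000 nM, with a range from 500 nM to 8000 nM, and a fair chance that the assay again reports only a limit.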

Compound 4, half-maximal effective concentration: 30 nM
The estimate for compound 4 lay 67-fold (1.82 log units) above the measured number, outside the stated range (below it).
By their numbers in this assay, from the lowest: compound 4; then compound 1; then compound 2. At a limit, above all of these: compound 3.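

On the aromatic carbon para to a large group, the result shows that this position is far from indifferent in this assay: piperidin-1-yl in place of dimethylamino gives an at least 33-fold lower number from compound 3 to compound 4 (1.52 log units; beyond the scatter). The two groups have the same counts of hydrogen-bond donors and acceptors and the same net charge, so what separates them on paper is the larger number of heavy atoms and the six-membered non-aromatic ring that piperidin-1-yl brings. Compound 3 reads > 1000 nM, which is a limit of the assay and not a number, so the step can be given only as a minimum: the limit of > 1000 nM in this assay, at which 1 of the 4 values shown sits.

The compounds shown leave open whether the ring itself matters or only the added carbons, a question that a diethylamino group at the same place would help to separate. They also leave open whether the nitrogen attached to the aromatic ring is needed at all, and a cyclohexyl group, or a morpholin-4-yl group with its added oxygen, would speak to how much of the piperidine can be changed.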